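The source may report more compounds than this note shows. Statements on the series, on what has been measured and on what is new or still open speak of the compounds shown alone.

In a functional assay on A549 cells (Homo sapiens) for inhibition, read by sulforhodamine B assay, with a stated time of 48 h (a lower number here means a stronger inhibitor, a higher number a weaker inhibitor), the three measured compounds give the following numbers:

Compound 1, `CCOC(=O)CCO/N=C(/c1ccc(OC)c(OC)c1OC)c1cccc2ccccc12`: 19600 nM
Compound 2, `COc1ccc(/C(=N/O)c2cccc3ccccc23)c(OC)c1OC`: 13100 nM
Compound 3, `COc1ccc(C(O)(Cc2ccc(C)cc2)c2cccc3ccccc23)c(OC)c1OC`: 18700 nM

Compound 2 gives the lowest of these three numbers, yet its gaps to compound 3 and to compound 1 both lie within the scatter of repeated measurements, so the three compounds stand as one group with no order among them. Compound 4, `CCOC(=O)CO/N=C(/c1ccc(OC)c(OC)c1OC)c1cccc2ccccc12`, is the compound still to be measured in this assay. It differs from compound 2 by (ethoxycarbonyl)methyl in place of hydrogen on an oxygen. Among the compounds with values here, only one measured step bears on this change: a 1.5-fold lower number from compound 1 to compound 2 (0.17 log units; within the scatter), which took away the 2-(ethoxycarbonyl)ethyl group from the same oxygen and left the number within the scatter. Compound 4 puts a shorter ester-bearing chain back onto that oxygen, so the expected outcome is a step of like size in the reverse direction, or none beyond the scatter, expressed as a 1.3-fold higher number from compound 2 to compound 4 (0.11 log units; within the scatter). Compound 4 is therefore estimated to give 17000 nM, with a range from 8000 nM to 40000 nM.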

Compound 4, half-maximal inhibitory concentration: 6720 nM
Estimate against measurement, compound 4: 2.5-fold (0.40 log units) above; measured number below the stated range.
By their numbers in this assay, from the lowest: compounds 4, 2, 3 and 1 (each within the scatter of the next, the first and the last beyond it).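

In this assay, the step from the free hydroxy to (ethoxycarbonyl)methoxy on this oxygen, a 1.9-fold lower number from compound 2 to compound 4 (0.29 log units; within the scatter), stays within the scatter, so the oxygen carries this group of 6 heavy atoms, with its loss of the hydroxy hydrogen, without a change that the assay can resolve. Within the data shown here, the comparison between the two ester-bearing chains is what the earlier compounds could not offer, and it gives a 2.9-fold lower number from compound 1 to compound 4 (0.46 log units; beyond the scatter), a modest step beyond the scatter, which shows that the length of the chain joining the ester to this oxygen can register in this assay even though neither ester-bearing compound stands clear of the free hydroxy compound 2. No measurement at hand accounts for this difference between the two chains, and the step stands here as an observation only.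

Among these compounds, it remains open whether the trend with chain length extends past these two esters, since a longer chain carrying the same ethyl ester would be needed to test it, and only two chain lengths are compared here. It is equally open whether the ester matters at all on this oxygen, as a carboxylic acid or an amide at the end of the (ethoxycarbonyl)methyl chain lies outside the compounds shown.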